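The source may report more compounds than this note shows. Statements on the series, on what has been measured and on what is new or still open speak of the compounds shown alone.

Of the compounds shown here, two sharing a common core have been tested in a functional assay on HeLa cells (Homo sapiens) for antiproliferative activity, with a stated time of 24 h; a higher number here means a weaker inhibitor, a lower number a stronger inhibitor. Compound 1, with the structure `NC(=O)c1c(NC(=O)c2ccccc2Cl)sc2c1CCN(C(=S)Nc1ccccc1F)C2`, gives 28700 nM in this assay. Compound 2, with the structure `NC(=O)c1c(NC(=O)c2ccccc2C(F)(F)F)sc2c1CCN(C(=S)Nc1ccccc1Cl)C2`, gives 46900 nM in this assay. These two values lie within the usual scatter of repeated measurements of each other, so the numbers do not separate compound 1 from compound 2; both sit in the weak range of the scale used here.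

Compound 3, with the structure `NC(=O)c1c(NC(=O)c2cccc([N+](=O)[O-])c2)sc2c1CCN(C(=S)Nc1ccccc1Cl)C2`, has not yet been measured. It differs from compound 2 in a single place: 3-nitrophenyl in place of 2-(trifluoromethyl)phenyl on a carbonyl carbon. For the measured compounds named here, no pair of measured compounds in this set differs at that position, so the data give no direct guide to the size or direction of such a change. With both measured compounds at similar, weak values, the expectation for compound 3 is a step of a 1.2-fold lower number from compound 2 to compound 3 (0.07 log units; within the scatter), which means no change beyond the scatter. On that basis compound 3 is estimated to give 40000 nM in this assay, with a likely range from 14000 nM to 115000 nM.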

Compound 3, half-maximal inhibitory concentration: 40300 nM
The estimate for compound 3 lay 1.0-fold (0.00 log units) below the measured number; measured number inside the range.
By their numbers in this assay, from the lowest: compounds 1, 3 and 2 (each within the scatter of the next).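

In this assay, for the compounds shown here, putting 3-nitrophenyl in place of 2-(trifluoromethyl)phenyl on the carbonyl carbon gives a 1.2-fold lower number from compound 2 to compound 3 (0.07 log units; within the scatter) and so provides the first direct reading at this position: the change does not separate the two compounds. The exchange is a sizeable one in what is counted, since the leaving group has three fluorine atoms and no hydrogen-bond acceptors, while the entering group has a nitrogen, two oxygens and 2 hydrogen-bond acceptors, yet for this one pair the number stays within the scatter. No separate measurement bears on why these two groups read alike.

Going by these compounds, it remains open whether a group of another kind on this carbonyl carbon, such as a phenyl ring carrying an amine or a carboxylic acid, or a longer chain in place of the ring, would move the number beyond the scatter. One pair also cannot show whether the same exchange would read alike with a different group elsewhere on the shared core.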